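The source may report more compounds than this note shows. Statements on the series, on what has been measured and on what is new or still open speak of the compounds shown alone.

Compound 1, `N#Cc1c(N2CCC(c3ccccc3)CC2)ccn2c(CC3CC3)nnc12`: 74 nM in a functional assay on CHO cells for positive allosteric modulation of metabotropic glutamate receptor 2 (Homo sapiens), read by GTPgammaS binding, with a stated time of 30 min; a lower number here means that less compound is needed, a higher number that more compound is needed for the effect
Compound 2, `COCc1nnc2c(C#N)c(N3CCC(c4ccccc4)CC3)ccn12`: 468 nM in this assay

For the measured compounds named here, compound 2 stands at the higher of these two numbers in this assay; its nearest neighbor is compound 1, and the single measured step between them, a 6.3-fold higher number from compound 1 to compound 2 (0.80 log units; beyond the scatter), is the only one that bears on what follows. Compound 3, `N#Cc1c(N2CCC(c3ccccc3)CC2)ccn2c(CN3CCCC3)nnc12`, differs from compound 2 by pyrrolidin-1-yl in place of methoxy on a saturated chain carbon bound to an aromatic carbon. The methoxy that this one step had introduced leaves again and a ring takes its place, so the number in this assay is expected to fall, by roughly a 2.3-fold lower number from compound 2 to compound 3 (0.37 log units; beyond the scatter). Compound 3 is therefore estimated at 200 nM, within a range from 60 nM to 700 nM.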

Compound 3, half-maximal effective concentration: 1120 nM
For compound 3 the middle estimate is 5.6-fold (0.75 log units) below the measured one, outside the stated range (above it).
By their numbers in this assay, from the lowest: compound 1; then compound 2; then compound 3.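

In this assay, swapping methoxy for pyrrolidin-1-yl on the saturated chain carbon moves the number further from compound 1, not back towards it, giving a 2.4-fold higher number from compound 2 to compound 3 (0.38 log units; beyond the scatter) and, against the cyclopropyl group, a 15-fold higher number from compound 1 to compound 3 (1.18 log units; beyond the scatter). A ring alone is therefore not enough for a low number at this place: compound 1 and compound 3 both carry one here, yet they stand furthest apart of the three. Nothing available explains this difference. As far as these compounds go, it remains open how an open-chain amine such as dimethylamino, or a longer carbon chain, would behave at this place.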